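A few compounds are considered here, and "the series" means these few. Any claim that something is new, unique, unknown or untested is made for them only; others in the source may bear on it.

Measured so far:
Compound 1, `CC(=O)OCc1ccc2oc(=O)c(C(=O)Oc3cccc(Br)c3)cc2c1`, gives 39.5% in a functional assay on HT-1080 cells (Homo sapiens), read by transwell migration, with a stated time of 24 h, tested at 0.1 uM; on this read-out lower numbers stand for a stronger effect and higher numbers for a weaker effect at the one concentration tested.
Compound 2, `CC(=O)OCc1ccc2oc(=O)c(C(=O)Sc3cccc(Cl)c3)cc2c1`, gives 76.5% in this assay.

Compound 1 stands lowest of the two numbers, which on this read-out means the stronger effect on cell migration at the single concentration tested. Within the data shown here, its only measured neighbour is compound 2, and the step between them, a number 37 percentage points higher from compound 1 to compound 2 (beyond the scatter), came from putting (3-chlorophenyl)sulfanyl in place of 3-bromophenoxy on a carbonyl carbon, that is, from altering the ester-bearing side of the shared core.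

Compound 3, `CCCCCC(=O)OCc1ccc2oc(=O)c(C(=O)Oc3cccc(Br)c3)cc2c1`, has not yet been measured. It differs from compound 1 by butyl in place of hydrogen on a saturated chain carbon bound to a carbonyl carbon; read one bond further out, the acetyl becomes pentylcarbonyl while the 3-bromophenoxy ester is kept exactly as in compound 1. Among the measured compounds shown here, no measured step touches this side of the molecule, and the one step that is known concerns a different position, so nothing in the data argues for a large move. The expected step for compound 3 is therefore small, a number 5.5 percentage points higher from compound 1 to compound 3 (within the scatter), not beyond the scatter. Compound 3 is estimated at 45%, with a range from 25% to 70%.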

Compound 3, a percentage reported as activity, at one concentration (the size of the read-out at that concentration, not a potency): 94.3%
Compound 3: the middle estimate sits 49.3 percentage points below what was measured; measured number outside the range, above it.
By their numbers in this assay, from the lowest: compound 1; then compound 2; then compound 3.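

Among these compounds, until now the only measured change sat on the other side of the shared core, on the carbonyl carbon holding the 3-bromophenoxy group. This result shows that the acetoxy side also matters in this assay: with the 3-bromophenoxy ester kept exactly as it was, going from acetyl to pentylcarbonyl gives a number 54.8 percentage points higher from compound 1 to compound 3 (beyond the scatter), a much weaker effect on cell migration at the one concentration tested, and a step larger than the one seen on the other side. So this chain position is not a place where added carbons pass without consequence, though nothing measured here gives a reason for the loss.

With only methyl and pentyl at this place, the compounds shown cannot tell whether the effect fades step by step as the chain grows or falls away at one particular length, which an ethyl or propyl chain would help to settle. They also leave open whether a chain ending in an amine or a carboxylic acid would behave like pentyl, and whether the same change would cost as much with the (3-chlorophenyl)sulfanyl group of compound 2 in place.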